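The source may report more compounds than this note shows. Statements on the series, on what has been measured and on what is new or still open speak of the compounds shown alone.

Within the data shown here, compound 1 `Cc1ccc(N2CCN(C(=O)Nc3nc4ccc(F)cc4s3)CC2)nn1` is one of only two compounds measured so far in an assay on HEK293 cells for inhibition of transient receptor potential cation channel subfamily V member 1 (Homo sapiens), read by FLIPR; on this read-out lower numbers stand for stronger inhibition and higher numbers for weaker inhibition. In this assay compound 1 gives only a limit, > 10000 nM, and not a number. Compound 2 `O=C(Nc1ccc(C(F)(F)F)cc1)N1CCN(c2cccnn2)CC1` likewise returns a limit in this assay, > 10000 nM. Both results thus sit at the limit of > 10000 nM in this assay, at which 2 of the 2 values shown sit, so compound 1 stands level with the only other compound shown, with no order between them.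

Compound 3 `O=C(Nc1nc2ccc(F)cc2s1)N1CCN(c2cccnn2)CC1` is not yet measured. It differs from compound 1 in one place: hydrogen in place of methyl on an aromatic carbon, which cut one bond further out reads 6-methylpyridazin-3-yl to pyridazin-3-yl. Among the measured compounds shown here, no measured pair shows this change, so the size of the step cannot be read from the data; compound 2 carries the same pyridazin-3-yl group as compound 3 and also sits at the limit. Compound 3 is expected to remain at the limit in this assay, with an estimate of 15000 nM and a range from 5000 nM to 50000 nM. The expected step from compound 1 to compound 3, a step that the limit leaves unreadable from compound 1 to compound 3, is none beyond the scatter.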

Compound 3, half-maximal inhibitory concentration: > 10000 nM
Compound 3 gave a limit, no number; the forecaster's own chance of this, stated with the estimate: 85%; the middle value is on the limit's open side.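

Compound 3, like compound 1, returns only a limit in this assay, so the change from 6-methylpyridazin-3-yl to pyridazin-3-yl gives no readable step: the limit of > 10000 nM in this assay, at which 3 of the 3 values shown sit.

What the compounds shown leave open is whether this methyl has any effect on inhibition, since none of them gives a number.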